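Shortening the side chain on the thiazolidine-type core

A few compounds are considered here, and "the series" means these few. Any claim that something is new, unique, unknown or untested is made for them only; others in the source may bear on it.

Compound 1, `C#CC(=O)N1C(C(CC)CCCC)SC[C@@H]1C(=O)OCC`, was tested in a functional assay on Huh-7 cells (Homo sapiens) for inhibition, read by sulforhodamine B assay (on this read-out lower numbers stand for stronger inhibition and higher numbers for weaker inhibition), where compound 1 gives 1700 nM. Two further compounds share its core and differ only in the group on the saturated ring carbon. Compound 2, `C#CC(=O)N1C(c2ccc(OC)cc2)SC[C@@H]1C(=O)OCC`, gives 1400 nM in this assay, and compound 3, `C#CC(=O)N1C(CC(C)CC(C)(C)C)SC[C@@H]1C(=O)OCC`, gives 1600 nM. Among the compounds with values here, the numbers of compound 1, compound 2 and compound 3 all lie within the scatter of one another, so none of the three can be set apart from the others on these data; compound 1 stands among them, with no step to either that goes beyond the scatter.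

Compound 4, `C#CC(=O)N1C(C(C)CCC)SC[C@@H]1C(=O)OCC`, has not yet been measured. It differs from compound 1 in a single place: 1-methylbutyl in place of 1-ethylpentyl on a saturated ring carbon. Within the data shown here, no pair of measured compounds shows this kind of shortening of a saturated chain, so the size of the step is not known from the data; since compound 1, compound 2 and compound 3 give numbers within the scatter of one another despite quite different groups at this position, the change is expected to be small, with no direction beyond the scatter.

Compound 4 is therefore expected to give about 2000 nM in this assay, in a range from 900 nM to 4500 nM, which means an expected step of a 1.2-fold higher number from compound 1 to compound 4 (0.07 log units; within the scatter).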

Compound 4, half-maximal inhibitory concentration: 600 nM
Beside the measured number, compound 4's estimate is 3.3-fold (0.52 log units) above it; the measured number lies below the stated range.
By their numbers in this assay, from the lowest: compound 4; then compounds 2, 3 and 1 (each within the scatter of the next).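

In this assay, replacing 1-ethylpentyl with 1-methylbutyl on the saturated ring carbon gives a 2.8-fold lower number from compound 1 to compound 4 (0.45 log units; beyond the scatter) and so moves the number beyond the scatter. This shows that the position does respond to the group it carries, which could not be seen from compound 1, compound 2 and compound 3, whose numbers all lie within the scatter of one another despite their quite different groups. The finding rests on this one pair, and nothing available explains the step. The compounds shown do not tell whether a still shorter chain, such as propyl or methyl, would lower the number further, or whether the 1-methylbutyl chain marks a limit beyond which the number rises again. They also leave open how this position would respond to a chain carrying an amine or a carboxylic acid, and whether the step from 1-ethylpentyl to 1-methylbutyl would hold with the ethoxycarbonyl or ethynylcarbonyl group of the shared core replaced.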